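N-Aryl swap on the thiazolidinone core: isoxazolyl to pyridinyl

A few compounds are considered here, and "the series" means these few. Any claim that something is new, unique, unknown or untested is made for them only; others in the source may bear on it.

Measured so far:
compound 1 `CC(C)(C)c1conc1N1C(=O)CSC1c1cccc(C(=O)NCCCCc2ccccc2)c1` — > 1000 nM
compound 2 `COc1ccccc1N1C(=O)CSC1c1cccc(C(=O)NCCCCn2cccn2)c1` — 91.7 nM

In a functional assay on HOS-TE85 cells (Homo sapiens) for inhibition, read by CCK-8 assay, with a stated time of 72 h (on this read-out lower numbers stand for stronger inhibition and higher numbers for weaker inhibition), compound 1 gives only a limit, > 1000 nM, not a number. In this assay compound 2 gives 91.7 nM. For the measured compounds named here, compound 2 differs from compound 1 in more than one place, so the two values show only that a shared core can reach a measurable number; no single step is computed between them. Compound 1 thus stands at the limit of > 1000 nM in this assay, at which 1 of the 2 values shown sits.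

Compound 3 `O=C(NCCCCc1ccccc1)c1cccc(C2SCC(=O)N2c2ccccn2)c1` is not yet measured. It differs from compound 1 in one place: a group of 6 heavy atoms (5 carbon, 1 nitrogen; one six-membered aromatic ring with 1 hetero atom) in place of a group of 9 heavy atoms (7 carbon, 1 nitrogen, 1 oxygen; one five-membered aromatic ring with 2 hetero atoms), on an amide-type nitrogen in a ring.

Because compound 1 stands at the limit of > 1000 nM in this assay, at which 1 of the 2 values shown sits, any direction for this step is open. The expectation is that the step from compound 1 to compound 3 is an at least 1.2-fold lower number from compound 1 to compound 3 (0.09 log units; that floor lies within the scatter), a gain beyond the scatter, with a real chance that only a limit is seen again. Compound 3 is expected to give 800 nM, from 150 nM to 5000 nM.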

Compound 3, half-maximal inhibitory concentration: 19.7 nM
The estimate for compound 3 lay 41-fold (1.61 log units) above the measured number; the whole stated range lies above it.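

In this assay, pyridin-2-yl in place of the five-membered aromatic ring of compound 1 gives an at least 50-fold lower number from compound 1 to compound 3 (1.70 log units; beyond the scatter). For the compounds shown here, this is the first comparison that differs in one place, and it shows that a change on the amide-type nitrogen alone, with the rest of compound 1 kept, is enough to move a limit to a measured number. The size of the step is a floor rather than a measured gap because compound 1 rests on a limit: the limit of > 1000 nM in this assay, at which 1 of the 3 values shown sits.

Open, as far as these compounds go, is whether the ring nitrogen of pyridin-2-yl is needed at all, a question that plain phenyl, pyridin-3-yl or pyridin-4-yl on the same nitrogen would address. Also open, from the compounds shown here alone, is whether the step holds when an amine or a carboxylic acid is placed at the end of the amide chain.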